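The source may report more compounds than this note shows. Statements on the series, on what has been measured and on what is new or still open speak of the compounds shown alone.

Compound 1 `CN1C(=O)[C@@]2(c3ccccc31)N(C)C[C@@H](c1ccc(Cl)cc1)[C@@]21Cc2ccccc2C1=O` is the reference point of this set. In a functional assay on RPMI18226 cells (Homo sapiens) for antiproliferative activity, read by sulforhodamine B assay, with a stated time of 48 h, tested at 10 uM (on this read-out higher numbers stand for more inhibition at the one concentration tested (going by the name of the read-out) and lower numbers for less inhibition), compound 1 gives 86.6%. Compound 2 `COc1ccc([C@@H]2CN(C)[C@]3(C(=O)N(C)c4ccccc43)[C@]23Cc2ccccc2C3=O)cc1` carries the change methoxy in place of chloro on an aromatic carbon on the same core; in this assay compound 2 gives 82.3%, so the step of a number 4.3 percentage points lower from compound 1 to compound 2 (within the scatter) is small. Compound 3 `O=C(Nc1ccccc1)c1c(-c2ccc(Cl)cc2)cc(-c2ccccc2)nc1Nc1ccc(Cl)cc1` rests on a different core, and the difference between the two cores is not broken down here; in this assay compound 3 gives 53%, the lowest of the three measured numbers and beyond the scatter from both compound 1 and compound 2. Compound 4 `COc1ccc(Nc2nc(-c3ccccc3)cc(-c3ccc(Cl)cc3)c2C(=O)Nc2ccccc2)cc1` differs from compound 3 by methoxy in place of chloro on an aromatic carbon, the same change that separates compound 2 from compound 1, although read one bond further out it here turns (4-chlorophenyl)amino into (4-methoxyphenyl)amino. Within the data shown here, since the only measured instance of this change, a number 4.3 percentage points lower from compound 1 to compound 2 (within the scatter), stayed within the scatter, a step of about a number 3 percentage points lower from compound 3 to compound 4 (within the scatter) is expected from compound 3 to compound 4 in this assay. Compound 4 is therefore estimated at 50%, with a likely range from 35% to 65%.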

Compound 4, a percentage reported as inhibition, at one concentration (the size of the read-out at that concentration, not a potency): 30%
Compound 4: the middle estimate sits 20 percentage points above what was measured; measured number below the stated range.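

In this assay, methoxy in place of chloro on an aromatic carbon gives a step of a number 23 percentage points lower from compound 3 to compound 4 (beyond the scatter), where the same change sits in the (4-chlorophenyl)amino group. The size of the step therefore did not carry over from one core to the other: the same change on two cores in this assay, a number 4.3 percentage points lower (within the scatter) from compound 1 to compound 2 and a number 23 percentage points lower (beyond the scatter) from compound 3 to compound 4, 18.7 percentage points apart, beyond the scatter of two such steps. This shows that, in this series, a step read on the core of compound 1 is a poor guide to the step on the core of compound 3, but with one pair on each core it does not show why the two differ or give a rule for any further core.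

The compounds shown leave open how an amine, a hydroxyl or a longer alkoxy chain in the same place would read on either core. They also leave open whether the gap between the two steps would hold at other concentrations, since each number comes from a single concentration.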